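Two Pyrazolopyridine Nitriles and an Untested Nitrophenyl Analogue

A few compounds are considered here, and "the series" means these few. Any claim that something is new, unique, unknown or untested is made for them only; others in the source may bear on it.

Compound 1, `CCc1ccc(-c2nc3c(c(C)nn3-c3ccccc3)c(-c3ccccc3C(=O)O)c2C#N)cc1`: 33000 nM
Compound 2, `Cc1ccccc1-c1nc2c(c(C)nn2-c2ccccc2)c(-c2ccccc2O)c1C#N`: 21000 nM

In a physicochemical assay for solubility, read by spectrophotometry, in phosphate buffer, with a stated time of 18 h, at pH 7.4 (on this read-out higher numbers stand for higher solubility and lower numbers for lower solubility), compound 2 gives 21000 nM, the lower of the two numbers, though compound 1 with 33000 nM stands within the scatter of it. Among the measured compounds shown here, no step between measured compounds is available. Compound 3, `Cc1nn(-c2ccccc2)c2nc(-c3ccc([N+](=O)[O-])cc3)c(C#N)c(-c3ccccc3O)c12`, is not yet measured; it differs from compound 2 in this way: 4-nitrophenyl in place of 2-methylphenyl on an aromatic carbon. Compound 3 is estimated to give 12000 nM, with a range from 4000 nM to 40000 nM. The expected step of a 1.8-fold lower number from compound 2 to compound 3 (0.24 log units; within the scatter) is a modest fall, close to the edge of the scatter.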

Compound 3, solubility: 6000 nM
The estimate for compound 3 lay 2.0-fold (0.30 log units) above the measured number; the range from low to high includes it.
By their numbers in this assay, from the lowest: compound 3; then compounds 2 and 1 (each within the scatter of the next).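

At this aromatic carbon, next to the ring nitrogen and ortho to a cyano group, 4-nitrophenyl in place of 2-methylphenyl gives a 3.5-fold lower number from compound 2 to compound 3 (0.54 log units; beyond the scatter) in this assay. Among the compounds shown here, this is the first change in one place that can be read here, and it shows that the number moves with the group on this carbon. No measurement at hand accounts for the step.

Only this one exchange is shown at this carbon, so whether the nitro group itself goes with the lower number remains open. Going by these compounds, how 4-aminophenyl or 4-methoxyphenyl would stand there also remains open.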